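Rearranging the dichlorophenyl on the sulfonyl of compound 3

This account rests on a few compounds, and the source may have more. Where it says the series, first, only, none or still open, it means among the compounds named here.

Compound 3 `CC1CCN(C2CCN(S(=O)(=O)c3ccc(Cl)c(Cl)c3)CC2)CC1` holds the lowest number of the three measured in a functional assay on DLD-1 cells (Homo sapiens) for antiproliferative activity, read by CellTiter-Glo, with a stated time of 72 h; on this read-out lower numbers stand for stronger inhibition and higher numbers for weaker inhibition: compound 3 gives 2.9 nM. Its nearest neighbour is compound 1 `Cc1cccc(S(=O)(=O)N2CCC(N3CCC(C)CC3)CC2)c1`, which in this assay gives 25 nM; the step of an 8.6-fold lower number from compound 1 to compound 3 (0.94 log units; beyond the scatter) is beyond the scatter. Compound 2 `CC1CCN(C2CCN(S(=O)(=O)c3ccc(C#N)cc3)CC2)CC1` in this assay gives 2800 nM, and the step of a 970-fold lower number from compound 2 to compound 3 (2.98 log units; beyond the scatter) is the widest in the set, as is a 110-fold higher number from compound 1 to compound 2 (2.05 log units; beyond the scatter) from the other side.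

Compound 4 `CC1CCN(C2CCN(S(=O)(=O)c3ccc(Cl)cc3Cl)CC2)CC1` differs from compound 3 by 2,4-dichlorophenyl in place of 3,4-dichlorophenyl on a sulfonyl sulfur. Going by the values given here, no measured step bears directly on this change: all three steps swap one set of substituents on the aryl ring for another, whereas here the same two chlorines are kept and only their arrangement changes. What the measured steps do show is that the group on the sulfonyl sulfur moves the read-out over a wide span, so some shift is plausible, but its direction cannot be read from compound 1, compound 2 or compound 3. A modest weakening relative to compound 3 is the working expectation, with wide uncertainty. The expected step is a 4.1-fold higher number from compound 3 to compound 4 (0.62 log units; beyond the scatter). The number expected for compound 4 is 12 nM, with a range from 2.5 nM to 60 nM.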

Compound 4, half-maximal inhibitory concentration: 1 nM
Compound 4: middle estimate off by 12-fold (1.08 log units), on the high side, and the stated range ends above it.
By their numbers in this assay, from the lowest: compound 4; then compound 3; then compound 1; then compound 2.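

In this assay, rearranging the two chlorines on the sulfonyl sulfur gives a 2.9-fold lower number from compound 3 to compound 4 (0.46 log units; beyond the scatter), which shows that the read-out at this position depends on how the same atoms are arranged on the aryl ring, and not only on which substituents it carries. The step is modest but beyond the scatter, and it places compound 4 lowest of the four, with a 25-fold lower number from compound 1 to compound 4 (1.40 log units; beyond the scatter) and a 2800-fold lower number from compound 2 to compound 4 (3.45 log units; beyond the scatter), the latter now the widest span in the series. The data shown offer no explanation for the difference between the two dichlorophenyl groups.

The compounds shown leave open how much each chlorine contributes on its own, which a phenyl bearing a single chlorine on the sulfonyl sulfur would address, and whether bromine or methoxy in place of the chlorines would keep the number this low. On these data alone, it also remains open whether the preference for 2,4-dichlorophenyl over 3,4-dichlorophenyl would hold on a different core.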